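The source may hold more compounds than are shown below. What is called first, only, known or untested is meant among the compounds shown, and "the series" means these compounds.

Working notes on the series.

Compound 1 `O=C1CCCCC1C1CC(=O)N(c2ccccc2)C1=O` is the phenyl member of this small set; in an assay on Sf21 cells for inhibition of cytochrome c oxidase subunit 2 (Homo sapiens), read by spectrophotometry, with a stated time of 5 min (a lower number here means a stronger inhibitor, a higher number a weaker inhibitor), compound 1 gives 45100 nM. Compound 2 `O=C1CCCCC1C1CC(=O)N(Cc2ccccc2)C1=O` carries benzyl on the same nitrogen, and in this assay compound 2 gives 20000 nM. The step of a 2.3-fold lower number from compound 1 to compound 2 (0.35 log units; beyond the scatter) is the only one so far that concerns the group on the amide-type nitrogen in the ring. Compound 3 `CC1CCC(=O)C(C2CC(=O)N(Cc3ccccc3)C2=O)C1` adds a methyl on a saturated ring carbon of the cyclohexanone, and in this assay compound 3 gives 21900 nM, the second highest of the three numbers; the step of a 1.1-fold higher number from compound 2 to compound 3 (0.04 log units; within the scatter) shows that the methyl on its own leaves the number essentially where it was.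

Compound 4 `CC1CCC(=O)C(C2CC(=O)N(c3ccccc3)C2=O)C1` is not yet measured. It differs from compound 3 by phenyl in place of benzyl on an amide-type nitrogen in a ring, which is the reverse of the change seen between compound 1 and compound 2. Among the measured compounds shown here, with compound 3 as the starting point, the step of a 2.3-fold lower number from compound 1 to compound 2 (0.35 log units; beyond the scatter) is the one measured step that bears on it, and because a 2.3-fold lower number from compound 1 to compound 2 (0.35 log units; beyond the scatter) ran the other way, the number for compound 4 is expected to come out higher, by a modest margin, as a 2.2-fold higher number from compound 3 to compound 4 (0.34 log units; beyond the scatter). On that basis compound 4 is estimated at 48000 nM in this assay, with a range from 24000 nM to 100000 nM.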

Compound 4, half-maximal inhibitory concentration: 56500 nM
Estimate against measurement, compound 4: 1.2-fold (0.07 log units) below; low and high end bracket the measured number.
By their numbers in this assay, from the lowest: compounds 2 and 3 (each within the scatter of the next); then compounds 1 and 4 (each within the scatter of the next).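

The phenyl-for-benzyl change on the amide-type nitrogen in a ring now has a second reading in this assay, a 2.6-fold higher number from compound 3 to compound 4 (0.41 log units; beyond the scatter), and it agrees with the earlier reading on the core without the methyl: the same change on two cores in this assay, a 2.3-fold lower number (0.35 log units; beyond the scatter) from compound 1 to compound 2 and a 2.6-fold lower number (0.41 log units; beyond the scatter) from compound 4 to compound 3, 1.1-fold (0.06 log units) apart, within the scatter of two such steps. The methyl on a saturated ring carbon can now also be read with phenyl on the nitrogen, a 1.3-fold higher number from compound 1 to compound 4 (0.10 log units; within the scatter), and it stays within the scatter there as it did with benzyl: the same change on two cores in this assay, a 1.1-fold higher number (0.04 log units; within the scatter) from compound 2 to compound 3 and a 1.3-fold higher number (0.10 log units; within the scatter) from compound 1 to compound 4, 1.1-fold (0.06 log units) apart, within the scatter of two such steps. Across these four compounds, the two changes therefore read as independent of each other, with the size of the nitrogen step holding with or without the methyl, and no compound here goes against this.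

The compounds shown leave open whether a longer chain on that nitrogen, such as phenylethyl, would continue the step seen from phenyl to benzyl, and whether an amine or a carboxylic acid on the benzyl ring would move the number at all. They also leave open whether anything larger than methyl on the saturated ring, such as a hydroxyl or a tert-butyl group, would shift the number beyond the scatter.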